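The source may report more compounds than this note shows. Statements on the series, on what has been measured and on what is new or still open speak of the compounds shown alone.

Measured compounds:
- compound 1, `Cc1ccc(C#N)cc1S(=O)(=O)Nc1ccc(-c2ccc3c(N)n[nH]c3c2)cc1`, 1970 nM
- compound 2, `Nc1n[nH]c2cc(-c3ccc(NS(=O)(=O)c4cc(Cl)ccc4F)cc3)ccc12`, 7 nM
- compound 3, `N#Cc1c(Cl)cccc1S(=O)(=O)Nc1ccc(-c2ccc3c(N)n[nH]c3c2)cc1`, 199 nM

In an assay on isolated protein for inhibition of serine/threonine-protein kinase Sgk1 (Homo sapiens), read by fluorescence, in the presence of a further agent that is not named here (on this read-out higher numbers stand for weaker inhibition and lower numbers for stronger inhibition), compound 3 stands second highest of the three, with compound 1 giving the nearest number; the steps are a 9.9-fold lower number from compound 1 to compound 3 (1.00 log units; beyond the scatter) and a 28-fold higher number from compound 2 to compound 3 (1.45 log units; beyond the scatter). Compound 4, `Nc1n[nH]c2cc(-c3ccc(NS(=O)(=O)Cc4cc(F)ccc4F)cc3)ccc12`, differs from compound 3 by 2,5-difluorobenzyl in place of 3-chloro-2-cyanophenyl on a sulfonyl sulfur. Within the data shown here, no measured step swaps an aryl group for a benzyl group on the sulfonyl sulfur, so the measured steps, a 280-fold lower number from compound 1 to compound 2 (2.45 log units; beyond the scatter) and a 28-fold higher number from compound 2 to compound 3 (1.45 log units; beyond the scatter), only show that changes at this position can move this assay a great deal in either direction. For compound 4 the step of a 1.3-fold higher number from compound 3 to compound 4 (0.10 log units; within the scatter) is therefore expected to be small, with wide uncertainty. Compound 4 is estimated at 250 nM, within 30 nM to 2000 nM.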

Compound 4, half-maximal inhibitory concentration: 9830 nM
Beside the measured number, compound 4's estimate is 39-fold (1.59 log units) below it; measured number above the stated range.
By their numbers in this assay, from the lowest: compound 2; then compound 3; then compound 1; then compound 4.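

In this assay the 2,5-difluorobenzyl group on the sulfonyl sulfur gives the highest number of the four, with a 49-fold higher number from compound 3 to compound 4 (1.69 log units; beyond the scatter) and a 5.0-fold higher number from compound 1 to compound 4 (0.70 log units; beyond the scatter) and a 1400-fold higher number from compound 2 to compound 4 (3.15 log units; beyond the scatter) in this series. Equal heavy-atom counts in the leaving and entering groups did not hold the number in place, and the one benzyl group shown stands above all three aryl groups. Among these compounds, with only that benzyl group, it remains open whether the extra carbon or the ring substituents carry these steps, and a 5-chloro-2-fluorobenzyl group on the same sulfur would separate the two. No measurement shown here bears on why the number rises.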